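Rotarod toxicity of a dibutylamino analogue, estimated from its neighbours

The source may report more compounds than this note shows. Statements on the series, on what has been measured and on what is new or still open speak of the compounds shown alone.

Measured compounds in a toxicity assay on the whole organism with Mus musculus as the target, in the rotarod test; a lower number here means that less compound is needed, a higher number that more compound is needed for the effect:
compound 1 `CC1(C)C(=O)NC(c2ccc(N)cc2)c2ccccc21` gives 240 mg/kg
compound 2 `CC1(C)C(=O)NC(c2ccccc2N)c2ccccc21` gives > 1000 mg/kg
compound 3 `CCNCC(=O)Nc1ccc(C2NC(=O)C(C)(C)c3ccccc32)cc1` gives 760 mg/kg

Compound 2 gives only a limit of this assay, (the limit of > 1000 mg/kg in this assay, at which 1 of the 3 values shown sits), and not a number. Of the two numbers that were measured, compound 3 holds the higher one; its nearest neighbour is compound 1, and the step of a 3.2-fold higher number from compound 1 to compound 3 (0.50 log units; beyond the scatter) shows that adding the ((ethylamino)methyl)carbonyl group on the aromatic nitrogen raised the dose needed.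

Compound 4 `CCCCN(CCCC)CC(=O)Nc1ccc(C2NC(=O)C(C)(C)c3ccccc32)cc1` is not yet measured. It differs from compound 3 in one place: dibutylamino in place of ethylamino on a saturated chain carbon bound to a carbonyl carbon. For the measured compounds named here, no measured step changes this part of the molecule, so the only step that touches the region is the one from compound 1 to compound 3, which was modest in size and pointed upward. Going by the values given here, a change of the amine substituents alone gives no measured precedent, and the step to compound 4 is therefore expected to stay near the value of compound 3, within or just beyond the scatter. Compound 4 is expected to give about 800 mg/kg, between 350 mg/kg and 1500 mg/kg, which means an expected step of a 1.1-fold higher number from compound 3 to compound 4 (0.02 log units; within the scatter).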

Compound 4, dose for half-maximal effect: 600 mg/kg
Compound 4: middle estimate off by 1.3-fold (0.12 log units), on the high side; the range from low to high includes it.
By their numbers in this assay, from the lowest: compound 1; then compounds 4 and 3 (each within the scatter of the next). At a limit, above all of these: compound 2.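

In this assay, for the compounds shown here, this is the first look at the amine end of the side chain, where the earlier compounds offered only the step that added the whole side chain: dibutylamino in place of ethylamino on a saturated chain carbon bound to a carbonyl carbon gives a 1.3-fold lower number from compound 3 to compound 4 (0.10 log units; within the scatter). The entering group has 9 heavy atoms against 3 and 0 hydrogen-bond donors against 1, so at this position, in this one pair, a much larger group without the donor leaves the number within the scatter, and the two changes cannot be told apart because they arrive together. Nothing measured here gives a reason for this outcome.

From the compounds shown here alone, it remains open whether a smaller dimethylamino group, a ring amine such as piperidine, or a side chain with no amine at all, such as a plain acetyl group, would also leave the number within the scatter. Going by these compounds, it also remains open whether the side chain would act the same way on compound 2, which gives only a limit of the assay, > 1000 mg/kg.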